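Does a Small Chain Extension Repeat Its Earlier Step?

The source may hold more compounds than are shown below. What is called first, only, known or untested is meant among the compounds shown, and "the series" means these compounds.

Three compounds have been measured in a functional assay on KBVIN cells (Homo sapiens) for cytotoxicity, read by MTT assay, with a stated time of 72 h; on this read-out higher numbers stand for an effect only at larger amounts of compound and lower numbers for an effect already at smaller amounts:
compound 1 `CCc1cccc2c(OC)c(-c3occ(C)c3C(=O)OC)ccc12` gives 1.3 ug/mL;
compound 2 `CCOc1c(-c2occ(C)c2C(=O)OC)ccc2c(CC)cccc12` gives 1.7 ug/mL;
compound 3 `CCc1cccc2c(OC)c(-c3occ(C)c3COC)ccc12` gives 8.8 ug/mL.

Compound 1 and compound 2 differ by methyl in place of hydrogen on a saturated chain carbon bound to an oxygen on an aromatic ring, and this gave a 1.3-fold higher number from compound 1 to compound 2 (0.12 log units; within the scatter). Compound 3 differs from compound 1 by methoxymethyl in place of methoxycarbonyl on an aromatic carbon, a change that gave a 6.8-fold higher number from compound 1 to compound 3 (0.83 log units; beyond the scatter), so compound 3 stands with the highest number of the three.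

Compound 4 `CCOCc1c(C)coc1-c1ccc2c(CC)cccc2c1OC` has not yet been measured. It differs from compound 3 by methyl in place of hydrogen on a saturated chain carbon bound to an oxygen on a saturated carbon. Among the measured compounds shown here, this is the same kind of change as the one from compound 1 to compound 2, but not the same: there the place was a saturated chain carbon bound to an oxygen on an aromatic ring, here it is a saturated chain carbon bound to an oxygen on a saturated carbon.

Because the step of a 1.3-fold higher number from compound 1 to compound 2 (0.12 log units; within the scatter) stayed within the scatter, the step to compound 4 is expected to be small as well, around a 1.1-fold higher number from compound 3 to compound 4 (0.06 log units; within the scatter). Compound 4 is therefore estimated at 10 ug/mL, with a likely range from 5 ug/mL to 22 ug/mL in this assay.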

Compound 4, concentration for half-maximal effect: > 10 ug/mL
Compound 4 was reported as a limit; the forecaster's own chance of this, stated with the estimate: 5%; the middle value sits exactly at the limit.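

In this assay compound 4 gives > 10 ug/mL, which is a limit of the assay and not a number. Read as a floor, it gives an at least 1.1-fold higher number from compound 3 to compound 4 (0.05 log units; that floor lies within the scatter), and it also gives an at least 7.6-fold higher number from compound 1 to compound 4 (0.88 log units; beyond the scatter), so replacing methoxycarbonyl with ethoxymethyl on the core of compound 1 leaves a step beyond the scatter, while the floor for the added methyl alone stays within it. The two cases of adding this methyl show no clear gap, yet they do not establish that the change carries over equally from one core to the other: the same change on two cores in this assay, a 1.3-fold higher number (0.12 log units; within the scatter) from compound 1 to compound 2 and an at least 1.1-fold higher number (0.05 log units; that floor lies within the scatter) from compound 3 to compound 4; the limit leaves it open whether they differ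

The compounds shown leave open whether a longer chain in place of ethoxymethyl would give a readable number rather than another limit. They also leave open how an amine or a carboxylic acid at that same aromatic carbon would stand beside the methoxycarbonyl of compound 1, which gives 1.3 ug/mL.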